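The source may hold more compounds than are shown below. What is called first, only, known or untested is meant among the compounds shown, and "the series" means these compounds.

In a functional assay on MCF7 cells (Homo sapiens) for antiproliferative activity (on this read-out higher numbers stand for weaker inhibition and lower numbers for stronger inhibition), compound 1 `C#CCCCn1c(Cc2cc(OC)c(OC)c(OC)c2)nc2c(N)ncnc21` gives 24000 nM, compound 2 `CCC(CC)Cn1c(Cc2cc(OC)c(OC)c(OC)c2)nc2c(N)ncnc21` gives 158000 nM, and compound 3 `COCCn1c(Cc2cc(OC)c(OC)c(OC)c2)nc2c(N)ncnc21` gives 64600 nM, the second highest of the three numbers. Compound 4 `C/C=C/Cn1c(Cc2cc(OC)c(OC)c(OC)c2)nc2c(N)ncnc21` differs from compound 3 in one place: prop-1-en-1-yl in place of methoxymethyl on a saturated chain carbon bound to an aromatic nitrogen. Within the data shown here, two measured steps bear on this change. One is a 2.7-fold higher number from compound 1 to compound 3 (0.43 log units; beyond the scatter); the other is a 2.4-fold lower number from compound 2 to compound 3 (0.39 log units; beyond the scatter). The but-2-en-1-yl chain of compound 4 is closer in kind to the but-3-yn-1-yl chain of compound 1 than to the pentan-3-yl chain of compound 2, so a modest move back toward the number of compound 1 is expected in this assay. Compound 4 is therefore expected to give about 30000 nM, with a range from 12000 nM to 80000 nM. That estimate means a 2.2-fold lower number from compound 3 to compound 4 (0.33 log units; beyond the scatter).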

Compound 4, half-maximal inhibitory concentration: 51300 nM
Estimate against measurement, compound 4: 1.7-fold (0.23 log units) below, within the range that was stated.
By their numbers in this assay, from the lowest: compound 1; then compounds 4 and 3 (each within the scatter of the next); then compound 2.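

In this assay the change from 2-methoxyethyl to but-2-en-1-yl, which gives up the chain's hydrogen-bond acceptor, comes out as a 1.3-fold lower number from compound 3 to compound 4 (0.10 log units; within the scatter) and so shows no readable difference at this place. The but-2-en-1-yl chain still stands apart from the other two chains, with a 3.1-fold lower number from compound 2 to compound 4 (0.49 log units; beyond the scatter) and with a 2.1-fold higher number from compound 1 to compound 4 (0.33 log units; beyond the scatter) on the same read-out, so it does not match the but-3-yn-1-yl chain. Nothing measured here explains these differences.

Going by these compounds, whether an amine, a carboxylic acid or a longer unbranched chain at this place would move the number stays open. So does whether any chain here could give a lower number than the but-3-yn-1-yl chain.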